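Piperidine amides in the diaryl thioether series: acyl swap

The compounds below may be only part of what the source reports. "The series", "measured", "known", "first", "only" and "open" are said of these compounds alone.

Measured compounds in an assay on membranes from striatum (strain Sprague-Dawley) for displacement of a labelled ligand from sodium-dependent dopamine transporter (Rattus norvegicus), read by scintillation counting, with a stated time of 120 min; on this read-out lower numbers stand for stronger inhibition and higher numbers for weaker inhibition:
compound 1 `OC(Cc1ccccc1)CN1CCC(NCCSC(c2ccc(F)cc2)c2ccc(F)cc2)CC1` gives 31.4 nM
compound 2 `CC(C)(C)C(=O)N1CCC(NCCSC(c2ccc(F)cc2)c2ccc(F)cc2)CC1` gives 352 nM

Compound 2 holds the highest number of the two; its nearest neighbour is compound 1, separated by an 11-fold higher number from compound 1 to compound 2 (1.05 log units; beyond the scatter), a step that replaces an amine substituent with an amide and says little about one acyl group against another. Compound 3 `O=C(C1CC1)N1CCC(NCCSC(c2ccc(F)cc2)c2ccc(F)cc2)CC1` differs from compound 2 by cyclopropyl in place of tert-butyl on a carbonyl carbon. Among the measured compounds shown here, no measured step bears directly on this exchange; both remain amides of the same core. The expected outcome for compound 3 in this assay is therefore a step of a 1.2-fold lower number from compound 2 to compound 3 (0.07 log units; within the scatter), within the scatter, and compound 3 is estimated at 300 nM (range 120 nM to 800 nM).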

Compound 3, inhibition constant: 178 nM
Estimate against measurement, compound 3: 1.7-fold (0.23 log units) above, and the stated range covers the measured number.
By their numbers in this assay, from the lowest: compound 1; then compounds 3 and 2 (each within the scatter of the next).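

In this assay, cyclopropyl in place of tert-butyl on a carbonyl carbon gives a step within the scatter (a 2.0-fold lower number from compound 2 to compound 3 (0.30 log units; within the scatter)), so these two amides do not separate. The gap to the amine also holds with a second acyl group (a 5.7-fold higher number from compound 1 to compound 3 (0.75 log units; beyond the scatter)), so it is not particular to (tert-butyl)carbonyl. Nothing available explains either step. Open, from the compounds shown here alone, is whether a longer alkyl chain or a methoxymethyl group on the carbonyl carbon would stay in the same range as these two amides.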